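This account rests on a few compounds, and the source may have more. Where it says the series, first, only, none or still open, it means among the compounds named here.

Compound 2 `N#Cc1ccccc1-c1nc(N)c2cc(CN3CCC(F)CC3)sc2n1` carries a 2-cyanophenyl group on the shared core. In an assay on CHO-K1 cells for antagonist activity at adenosine receptor A1 (Homo sapiens), read by a beta-galactosidase reporter, with stated times of 15 min and 6 h (a lower number here means a stronger inhibitor, a higher number a weaker inhibitor), compound 2 gives 5050 nM, the higher of the two plain numbers recorded. Compound 1 `N#Cc1cccc(-c2nc(N)c3cc(CN4CCC(F)CC4)sc3n2)c1` gives 2950 nM, and the step of a 1.7-fold higher number from compound 1 to compound 2 (0.23 log units; within the scatter). Compound 3 `Nc1nc(-c2ccccc2C(F)(F)F)nc2sc(CN3CCC(F)CC3)cc12` gives > 10000 nM, which is a limit of the assay rather than a number, namely (the limit of > 10000 nM in this assay, at which 1 of the 3 values shown sits). The step of an at least 1.9-fold higher number from compound 2 to compound 3 (0.29 log units; that floor lies within the scatter). Compound 4 `Nc1nc(-c2cccc([N+](=O)[O-])c2)nc2sc(CN3CCC(F)CC3)cc12` changes (3-nitrophenyl in place of 2-cyanophenyl on an aromatic carbon). Both measured steps involve the cyano group or its position, and neither reaches beyond the scatter, so the step of a 1.7-fold lower number from compound 2 to compound 4 (0.23 log units; within the scatter) is expected to be small. Compound 4 is therefore estimated at 3000 nM, between 1000 nM and 10000 nM.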

Compound 4, inhibition constant: > 10000 nM
Compound 4 gave a limit, no number; the forecaster's own chance of this, stated with the estimate: 20%; middle value at least 3.3-fold (0.52 log units) away from the limit.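

Within the data shown here, replacing the nitrile of the 3-cyanophenyl group with nitro gives an at least 3.3-fold higher number from compound 1 to compound 4 (0.53 log units; beyond the scatter) at this position, the first step that clears the scatter. Measured against the 2-cyanophenyl group, the change gives an at least 1.9-fold higher number from compound 2 to compound 4 (0.29 log units; that floor lies within the scatter) and so shows no clear difference in size. In this assay compound 4 stands at a limit, not a number, as compound 3 does: the limit of > 10000 nM in this assay, at which 2 of the 4 values shown sit.

From the compounds shown here alone, how far compound 4 lies past that limit stays unknown. Going by these compounds, what an amine or a carboxylic acid on the phenyl ring would do also remains open.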